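This account rests on a few compounds, and the source may have more. Where it says the series, first, only, none or still open, it means among the compounds named here.

Of the compounds shown here, three have been tested in an ADME assay on MT4 cells (Homo sapiens) for cytotoxicity, read by MTT assay; on this read-out lower numbers stand for higher toxicity in this test and higher numbers for lower toxicity in this test. Compound 1 `Cc1cc(C)cc(CSc2nc(Cc3c(F)cccc3F)c(C)c(=O)[nH]2)c1` reads > 65000 nM, which is a limit of the assay. Compound 2 `CC(C)Sc1nc(Cc2c(F)cccc2F)cc(=O)[nH]1` reads > 84000 nM, also a limit. Within the data shown here, compound 3 `COc1ccc(CSc2nc(Cc3c(Cl)cccc3Cl)c(C)c(=O)[nH]2)cc1` gives 32000 nM, the only actual number of the three. Compound 4 `Cc1c(Cc2c(Cl)cccc2Cl)nc(SCC(=O)c2ccccc2)[nH]c1=O` differs from compound 3 as follows: benzoyl in place of 4-methoxyphenyl on a saturated chain carbon bound to a sulfur. Among the measured compounds shown here, no measured pair differs in one place only, so the expectation starts from compound 3 at 32000 nM, and no step beyond the scatter is expected in this assay. The estimated change, a 1.1-fold higher number from compound 3 to compound 4 (0.04 log units; within the scatter), is expected to stay small. For compound 4 the expected value is 35000 nM, with an estimated range from 12000 nM to 90000 nM.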

Compound 4, half-maximal cytotoxic concentration: > 60000 nM
Compound 4 ended at the assay's limit; the forecaster's own chance of this, stated with the estimate: 35%; middle value at least 1.7-fold (0.23 log units) away from the limit.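

At this position on a saturated chain carbon bound to a sulfur, benzoyl in place of 4-methoxyphenyl gives an at least 1.8-fold higher number from compound 3 to compound 4 (0.27 log units; that floor lies within the scatter) in this assay. Compound 4 reads > 60000 nM, which is a limit of the assay. Among these compounds, this is the first view of this position with the rest of the compound unchanged, and it shows only that the change brings no lower number, while the true size of the step cannot be read.

The compounds shown do not separate the carbonyl from the methoxy group as the source of the step. Going by these compounds, how an amine or a carboxylic acid at this position would read also stays open.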